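The compounds below may be only part of what the source reports. "The series", "measured", "known", "first", "only" and "open" are said of these compounds alone.

The compounds here share a core and differ in one group, and they are compared in a functional assay on the whole organism for activation, with Mus musculus as the target, with a stated time of 60 min; on this read-out higher numbers stand for an effect only at larger amounts of compound and lower numbers for an effect already at smaller amounts. Compound 1 (`CC(=O)Nc1ccc(-c2ccc(/C=N/N3C(=O)NC(=O)C3O)o2)cc1`) gives > 1000 mg/kg, which is a limit of the assay and not a number. Compound 2 (`Nc1ccc(-c2ccc(/C=N/N3C(=O)NC(=O)C3O)o2)cc1`), with hydrogen in place of acetyl on a nitrogen on an aromatic ring, gives > 1000 mg/kg, which is also a limit. Between these two lies a step that the two limits leave unreadable from compound 1 to compound 2. Compound 2 therefore has no exact value and stands only at the limit of > 1000 mg/kg in this assay, at which 2 of the 2 values shown sit.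

The next structural change leads to compound 3 (`O=C1NC(=O)N(/N=C/c2ccc(-c3ccc(F)cc3)o2)C1O`), with fluoro in place of amino on an aromatic carbon, para to a large group: fluoro in place of amino on an aromatic carbon. Within the data shown here, the only measured step changes the amino group of compound 2 as well, but it has no readable size, so it gives no guide to the size or direction of this new change. With so little to go on, the estimated change is a number no higher from compound 2 to compound 3 (the limit leaves the size open), and no direction can be firmly expected. The expected value for compound 3 is 1000 mg/kg, with an estimated range from 300 mg/kg to 3000 mg/kg.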

Compound 3, dose for half-maximal effect: 1000 mg/kg
Compound 3: middle estimate and measured number agree at the digits printed; the range from low to high includes it.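

In this assay compound 3 gives 1000 mg/kg as the only exact number among the compounds shown, so fluoro on an aromatic carbon, para to a large group, gives a value that can be read as a number. There is a number no higher from compound 2 to compound 3 (the limit leaves the size open) and a number no higher from compound 1 to compound 3 (the limit leaves the size open) and neither can be read, so neither the size of the change from amino or acetamido to fluoro nor any gain in potency can be stated. The other two compounds still give no number to measure against: the limit of > 1000 mg/kg in this assay, at which 2 of the 3 values shown sit.

As far as these compounds go, it remains open whether other groups at this place, such as chloro, methoxy or a carboxylic acid, would give an effect at smaller or larger amounts of compound than fluoro does. A second exact value on the same core would be needed before the size of any step at this position could be read.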